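This account rests on a few compounds, and the source may have more. Where it says the series, first, only, none or still open, it means among the compounds named here.

The series shares one urea core and varies a single substituent on the aryl ring. Compound 1 `C[C@@H](NC(=O)Nc1cccc(C(F)(F)F)c1)c1ccccc1` carries a trifluoromethyl group there and gives 72% in an ADME assay on the whole organism with Oryza sativa as the target, tested at 1 uM; on this read-out higher numbers stand for a weaker effect at the one concentration tested and lower numbers for a stronger effect. Compound 2 `COc1cccc(NC(=O)N[C@H](C)c2ccccc2)c1` carries a methoxy group and gives 92% in this assay. Compound 3 `C[C@@H](NC(=O)Nc1cccc(Cl)c1)c1ccccc1` carries a chloro group and gives 91% in this assay. Among these three numbers compound 3 stands second highest: its nearest neighbour is compound 2, and a number 1 percentage points lower from compound 2 to compound 3 (within the scatter) lies within the scatter, so the two are not distinguishable; its furthest is compound 1, and a number 19 percentage points higher from compound 1 to compound 3 (beyond the scatter) lies beyond the scatter.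

Compound 4 `C[C@@H](NC(=O)Nc1cccc(Br)c1)c1ccccc1` follows from compound 3 by a single change: bromo in place of chloro on an aromatic carbon. For the measured compounds named here, no measured step exchanges one halogen for another, so the closest guidance comes from the two steps that end at compound 3. a number 19 percentage points higher from compound 1 to compound 3 (beyond the scatter) was modest, and a number 1 percentage points lower from compound 2 to compound 3 (within the scatter) was within the scatter; a small change at this one aromatic carbon has thus produced at most a modest shift, and the exchange of chloro for bromo is smaller than either of those. The step of a number 2 percentage points lower from compound 3 to compound 4 (within the scatter) is therefore expected to fall within the scatter. Compound 4 is estimated to give 89% in this assay, with a range from 76% to 98%.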

Compound 4, a percentage reported as activity, at one concentration (the size of the read-out at that concentration, not a potency): 100%
Estimate against measurement, compound 4: 11 percentage points below, and the stated range ends below it.
By their numbers in this assay, from the lowest: compound 1; then compounds 3, 2 and 4 (each within the scatter of the next).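

In this assay, for the compounds shown here, the exchange of chloro for bromo gives the first step between two halogens on this aromatic carbon, meta to a large group, and a number 9 percentage points higher from compound 3 to compound 4 (within the scatter) does not separate the two. Bromo is likewise not separated from methoxy, with a number 8 percentage points higher from compound 2 to compound 4 (within the scatter) for that exchange, while a number 28 percentage points higher from compound 1 to compound 4 (beyond the scatter) for the exchange of trifluoromethyl for bromo adds a third step from compound 1 that lies beyond the scatter, so that among these four compounds only compound 1 stands apart, with the lowest number and thus the strongest effect at the one concentration tested, and compounds 2, 3 and 4 cannot be told apart. Nothing available here explains why the trifluoromethyl compound differs from the other three.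

Going by these compounds, it remains open whether trifluoromethyl is alone in this at the position, or whether a nitrile, an amine or a carboxylic acid on the same aromatic carbon would give a similarly low number. The compounds shown also leave open whether the gap between trifluoromethyl and the other groups would hold with any change elsewhere on the shared core.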